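This account rests on a few compounds, and the source may have more. Where it says the series, first, only, none or still open, it means among the compounds named here.

In an ADME assay on HEK293 cells (Homo sapiens) for cytotoxicity, read by fluorescence and resazurin assay, with a stated time of 24 h (a higher number here means that more compound is tolerated, a lower number that less compound is tolerated), compound 1 `O=S1(=O)C=C(Sc2nnc(-c3ccccn3)o2)c2ccccc21` gives 5000 nM and compound 2 `Cc1ccc(-c2nnc(SC3=CS(=O)(=O)c4ccccc43)o2)cc1` gives 3000 nM, so these two values cannot be told apart beyond the usual scatter. Compound 3 `O=S1(=O)C=C(Sc2nnc(-c3ccc(Cl)cc3)o2)c2ccccc21` keeps the shared core and differs from compound 2 by chloro in place of methyl on an aromatic carbon. Among the measured compounds shown here, only one measured step bears on this: a 1.7-fold lower number from compound 1 to compound 2 (0.22 log units; within the scatter), with 4-methylphenyl in place of pyridin-2-yl, and it stays within the scatter. The expected step is therefore small, a 1.1-fold lower number from compound 2 to compound 3 (0.03 log units; within the scatter), with no clear direction. The estimated value for compound 3 is 2800 nM, with an expected range from 1200 nM to 6500 nM.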

Compound 3, half-maximal cytotoxic concentration: 3000 nM
The estimate for compound 3 lay 1.1-fold (0.03 log units) below the measured number; measured number inside the range.
By their numbers in this assay, from the lowest: compounds 2, 3 and 1 (each within the scatter of the next).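

Putting chloro in place of methyl on this aromatic carbon, para to a large group, gives no change at the digits printed from compound 2 to compound 3 (within the scatter), so the two groups cannot be told apart in this assay. Replacing pyridin-2-yl with 4-chlorophenyl gives a 1.7-fold lower number from compound 1 to compound 3 (0.22 log units; within the scatter), and this also stays within the scatter, as does the earlier change to 4-methylphenyl. No measurement here explains these numbers. Going by these compounds, it remains open whether an amine, a carboxylic acid or a longer chain at this position would shift the tolerated concentration beyond the scatter.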